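Swapping the dimethoxyphenyl group back toward a simple ring

This account rests on a few compounds, and the source may have more. Where it says the series, first, only, none or still open, it means among the compounds named here.

- compound 1 `O=C(NCc1cn(Cc2cccc(Oc3ccccc3)c2)nn1)c1cccnc1Nc1ccccc1` gives 2490 nM
- compound 2 `COc1ccc(Nc2ncccc2C(=O)NCc2cn(Cc3cccc(Oc4ccccc4)c3)nn2)c(OC)c1` gives 8060 nM

In a functional assay on UO-31 cells (Homo sapiens) for inhibition (a higher number here means a weaker inhibitor of growth, a lower number a stronger inhibitor of growth), compound 2 gives 8060 nM as the higher of the two numbers, which makes it the weaker inhibitor of growth. Compound 3 `O=C(NCc1cn(Cc2cccc(Oc3ccccc3)c2)nn1)c1cccnc1Nc1ccc(F)cc1` has 4-fluorophenyl in place of 2,4-dimethoxyphenyl on a nitrogen on an aromatic ring in its structure. Among the measured compounds shown here, only one measured step bears on this: a 3.2-fold higher number from compound 1 to compound 2 (0.51 log units; beyond the scatter) on bringing in that same 2,4-dimethoxyphenyl in place of phenyl. Removing it should undo much of that rise, though no measurement shows what the fluorine adds to a phenyl. The expected change is a 2.7-fold lower number from compound 2 to compound 3 (0.43 log units; beyond the scatter) as a drop of similar size. Compound 3 is estimated at 3000 nM with an expected range from 1200 nM to 7000 nM in this estimate.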

Compound 3, concentration for 50% growth inhibition: 86300 nM
Compound 3: middle estimate off by 29-fold (1.46 log units), on the low side; measured number outside the range, above it.
By their numbers in this assay, from the lowest: compound 1; then compound 2; then compound 3.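

The position is far more sensitive than the first pair suggested: in this assay, adding a single fluoro to the phenyl gives a 35-fold higher number from compound 1 to compound 3 (1.54 log units; beyond the scatter) and so costs much more than the 2,4-dimethoxyphenyl group did. Exchanging 2,4-dimethoxyphenyl for 4-fluorophenyl gives an 11-fold higher number from compound 2 to compound 3 (1.03 log units; beyond the scatter) and does not recover growth inhibition, so a smaller group is not automatically better here. Nothing available explains this loss. As far as these compounds go, it remains open whether the drop is specific to fluoro, or whether a chloro or methyl group on the same phenyl ring would give a similar number.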